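The compounds below may be only part of what the source reports. "The series", "measured", "known", "first", "only" and "open" are said of these compounds alone.

Working notes on the series. The shared core of compound 1 `CN(C)c1ccc(C#CC(C)(O)c2nccs2)cc1Nc1ncnc2[nH]ccc12` carries a dimethylamino group; in an assay for inhibition of mitogen-activated protein kinase kinase kinase 14 (Homo sapiens), read by luminescence and ADP-Glo, with a stated time of 120 min, in the presence of a further agent that is not named here (on this read-out lower numbers stand for stronger inhibition and higher numbers for weaker inhibition), compound 1 gives 22.5 nM. Going by the values given here, compound 2 `CN(C)CCN(C)c1ccc(C#CC(C)(O)c2nccs2)cc1Nc1ncnc2[nH]ccc12` carries the (2-(dimethylamino)ethyl)(methyl)amino group and in this assay compound 2 gives 484 nM, the highest of the three numbers so far. Compound 3 `CN1CCN(c2ccc(C#CC(C)(O)c3nccs3)cc2Nc2ncnc3[nH]ccc23)CC1` carries 4-methylpiperazin-1-yl and in this assay compound 3 gives 78.3 nM. The steps are a 22-fold higher number from compound 1 to compound 2 (1.33 log units; beyond the scatter), a 3.5-fold higher number from compound 1 to compound 3 (0.54 log units; beyond the scatter) and a 6.2-fold lower number from compound 2 to compound 3 (0.79 log units; beyond the scatter).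

Compound 4 `CC(O)(C#Cc1ccc(OC2CCOCC2)c(Nc2ncnc3[nH]ccc23)c1)c1nccs1` differs from compound 2 as follows: (oxan-4-yl)oxy in place of (2-(dimethylamino)ethyl)(methyl)amino on an aromatic carbon. Among the compounds with values here, no measured step bears directly on an amine-to-ether exchange at this carbon. What is known is that compound 2 stands well above both compound 1 and compound 3, so both recorded departures from its side chain lowered the number, one largely and one modestly. Within the data shown here, a modest fall is therefore expected in this assay for compound 4, namely a 6.1-fold lower number from compound 2 to compound 4 (0.78 log units; beyond the scatter), with wide uncertainty since no ether analogue has been measured. The estimate for compound 4 in this assay is 80 nM, with a range from 25 nM to 250 nM.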

Compound 4, half-maximal inhibitory concentration: 112 nM
The estimate for compound 4 lay 1.4-fold (0.15 log units) below the measured number, and the stated range covers the measured number.
By their numbers in this assay, from the lowest: compound 1; then compounds 3 and 4 (each within the scatter of the next); then compound 2.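

At this aromatic carbon, nitrogen is not needed for a number well below that of compound 2: replacing the open (2-(dimethylamino)ethyl)(methyl)amino chain with the ring-bearing (oxan-4-yl)oxy group gives a 4.3-fold lower number from compound 2 to compound 4 (0.64 log units; beyond the scatter) in this assay. The two six-membered ring groups cannot be separated, since the exchange of 4-methylpiperazin-1-yl for (oxan-4-yl)oxy gives a 1.4-fold higher number from compound 3 to compound 4 (0.16 log units; within the scatter), so in this set the oxygen-linked ring does as well as the nitrogen-linked one. Dimethylamino still holds the lowest number of the four, with a 5.0-fold higher number from compound 1 to compound 4 (0.70 log units; beyond the scatter).

Nothing given here accounts for these differences. Open, going by these compounds, is whether a methoxy group on this carbon, an ether without the ring, would come nearer to compound 1, and whether an (oxan-4-yl)amino group would match the ether.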